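The compounds below may be only part of what the source reports. "The series", "measured", "known", "first", "only" and "open" are said of these compounds alone.

Measured compounds:
compound 1, `CC1=C(/C=C/C(C)=C/C=C/C(C)=C\C(=O)NCc2ccc(F)cc2)C(C)(C)CCC1n1ccnc1`, 2450 nM
compound 2, `CC1=C(/C=C/C(C)=C/C=C/C(C)=C\C(=O)Nc2ccccc2)C(C)(C)CC=C1c1cccnc1`, 39800 nM
compound 3, `CC1=C(/C=C/C(C)=C/C=C/C(C)=C\C(=O)NCc2ccc(O)cc2)C(C)(C)CC=C1c1cncnc1`, 19100 nM

In a functional assay on MDA-MB-468 cells (Homo sapiens) for inhibition, read by MTT assay (a higher number here means a weaker inhibitor of growth, a lower number a stronger inhibitor of growth), compound 1 gives the lowest of the three numbers. The nearest to it is compound 3, whose value in this assay is 19100 nM, a gap beyond the scatter. Further away stands compound 2, which in this assay gives 39800 nM, also beyond the scatter. Compound 3 and compound 2 differ from compound 1 in more than one place, so neither of those gaps is tied to a single change.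

The unmeasured compound 4, `CC1=C(/C=C/C(C)=C/C=C/C(C)=C\C(=O)NCc2ccc(O)cc2)C(C)(C)CCC1n1ccnc1`, keeps the core of compound 1 and alters only the group on the benzyl ring: hydroxy in place of fluoro on an aromatic carbon. Read one bond further out, this is 4-fluorobenzyl to 4-hydroxybenzyl. Among the compounds with values here, no pair among the measured compounds isolates this change, and the 4-hydroxybenzyl in compound 3 sits on a different core, so its value cannot be carried over.

Within the data shown here, with no direct step to lean on, compound 4 is expected to stay near compound 1, with a step of a 1.4-fold higher number from compound 1 to compound 4 (0.15 log units; within the scatter) in this assay, likely within or only slightly beyond the scatter and, if anything, toward a higher number. Compound 4 is therefore estimated at 3500 nM in this assay, within a range from 1200 nM to 10000 nM.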

Compound 4, concentration for 50% growth inhibition: 2700 nM
Compound 4: the middle estimate sits 1.3-fold (0.11 log units) above what was measured, and the stated range covers the measured number.
By their numbers in this assay, from the lowest: compounds 1 and 4 (each within the scatter of the next); then compound 3; then compound 2.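

In this assay, the exchange of fluoro for hydroxy on an aromatic carbon, para to a large group, gives a 1.1-fold higher number from compound 1 to compound 4 (0.04 log units; within the scatter), so 4-fluorobenzyl and 4-hydroxybenzyl cannot be told apart on the core of compound 1. Within the data shown here, this is the first pair that differs only at this place, and it shows that one hydrogen-bond donor and one hydrogen-bond acceptor can enter there with no step beyond the scatter. Nothing at hand accounts for why the two groups read alike.

The compounds shown leave open how an amine, a carboxylic acid or a methoxy group would read at this same place on the core of compound 1, and so whether the result extends beyond these two small groups. They also leave open whether fluoro and hydroxy would read alike on the core of compound 3, which appears here only with the 4-hydroxybenzyl group.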